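The source may report more compounds than this note shows. Statements on the series, on what has been measured and on what is new or still open speak of the compounds shown alone.

Measured so far:

- compound 1, `CC1(C)[C@H]2CC[C@]1(C)N(Cc1cn(-c3ccccc3O)nn1)C(=O)C2`: 120 nM
- compound 2, `COc1ccccc1-n1cc(CN2C(=O)C[C@@H]3CC[C@@]2(C)C3(C)C)nn1`: 110 nM
- compound 3, `CC1(C)[C@H]2CC[C@]1(C)N(Cc1cn(-c3ccc(Br)cc3)nn1)C(=O)C2`: 110 nM

These numbers come from a functional assay on HepG2 cells (Homo sapiens) for inhibition, read by MTT assay, with a stated time of 24 h; a higher number here means a weaker inhibitor, a lower number a stronger inhibitor. Compound 3 stands level with compound 2 at the digits printed, and the two together give the lowest numbers of the three; its furthest companion is compound 1, with the step of a 1.1-fold lower number from compound 1 to compound 3 (0.04 log units; within the scatter).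

Compound 4, `Cc1cccc(-n2cc(CN3C(=O)C[C@@H]4CC[C@@]3(C)C4(C)C)nn2)c1`, is the next compound in this series. It differs from compound 3 in one place: 3-methylphenyl in place of 4-bromophenyl on an aromatic nitrogen

Going by the values given here, two measured steps bear on this change: a 1.1-fold lower number from compound 1 to compound 3 (0.04 log units; within the scatter) and no change at the digits printed from compound 2 to compound 3 (within the scatter). Each of them also swaps the group on the same aromatic nitrogen. Both lie within the scatter, so exchanging one such group for another has, so far, not moved the number in this assay. The same is therefore expected here: no step beyond the scatter, no change at the digits printed from compound 3 to compound 4 (within the scatter). Compound 4 is estimated at 110 nM, with a range from 55 nM to 220 nM.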

Compound 4, half-maximal inhibitory concentration: 300 nM
The estimate for compound 4 lay 2.7-fold (0.44 log units) below the measured number; the whole stated range lies below it.
By their numbers in this assay, from the lowest: compounds 2, 3 and 1 (each within the scatter of the next); then compound 4.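

The group on this aromatic nitrogen can matter after all: 3-methylphenyl gives a 2.7-fold higher number from compound 3 to compound 4 (0.44 log units; beyond the scatter) and a 2.7-fold higher number from compound 2 to compound 4 (0.44 log units; beyond the scatter) and also a 2.5-fold higher number from compound 1 to compound 4 (0.40 log units; beyond the scatter) in this series. Going by these compounds alone, all three steps are modest, yet they are the first here to pass beyond the scatter. The 4-bromophenyl and 3-methylphenyl groups match in heavy-atom, donor and acceptor counts, so those counts do not separate compound 3 from compound 4, and no measurement shown accounts for the step.

This swap changes both the substituent and its place on the phenyl ring, so the compounds shown cannot say which of the two matters. A 4-methylphenyl or 3-bromophenyl group would separate them, while a phenyl ring bearing an amine or a carboxylic acid would test a different kind of group.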